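Chromene chalcones: a pyridinyl replacement for the methoxyphenyl arm

The compounds below may be only part of what the source reports. "The series", "measured", "known", "first", "only" and "open" are said of these compounds alone.

Compound 1 `COc1cccc(/C=C/C(=O)c2ccc(OC)c3c2OC(C)(C)C=C3)c1` — 9360 nM
Compound 2 `COc1ccc(C(=O)/C=C/c2ccc3ccccc3c2)c2c1C=CC(C)(C)O2` — 7650 nM
Compound 3 `COc1ccc(C(=O)/C=C/c2ccc(OC)c(OC)c2OC)c2c1C=CC(C)(C)O2` — > 10000 nM

The three measured compounds share a chromene chalcone core and differ in the aryl arm on the double-bonded chain. In a functional assay on SK-OV-3 cells (Homo sapiens) for antiproliferative activity, read by MTT assay, with a stated time of 24 h (on this read-out lower numbers stand for stronger inhibition and higher numbers for weaker inhibition), compound 1 gives 9360 nM, the higher of the two numbers reported, and compound 2 gives 7650 nM, within the scatter of compound 1, so no order between them can be claimed. For compound 3 this assay returns only a limit, > 10000 nM, and not a number (the limit of > 10000 nM in this assay, at which 1 of the 3 values shown sits). Going by the values given here, no single-point step between measured compounds is available, so nothing measured here tells how a change on the double-bonded chain carbon moves potency.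

Compound 4 `COc1ccc(C(=O)/C=C/c2ccccn2)c2c1C=CC(C)(C)O2` is not yet measured. It differs from compound 1 by pyridin-2-yl in place of 3-methoxyphenyl on a double-bonded chain carbon bound to a double-bonded chain carbon. Without a measured step to lean on, the writer expects the move from compound 1 to compound 4 to stay roughly within the scatter, or to drift toward weaker inhibition given how close compound 1 already lies to the limit of this assay. The estimated step is a 1.0-fold higher number from compound 1 to compound 4 (0.01 log units; within the scatter). For compound 4 the estimate in this assay is 9500 nM, ranging from 3000 nM to 30000 nM, with a real chance that only a limit is reported.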

Compound 4, half-maximal inhibitory concentration: 8390 nM
For compound 4 the middle estimate is 1.1-fold (0.05 log units) above the measured one, within the range that was stated.
By their numbers in this assay, from the lowest: compounds 2, 4 and 1 (each within the scatter of the next). At a limit, above all of these: compound 3.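

Going by these compounds alone, this is the first single-point step in the set: in this assay, pyridin-2-yl in place of 3-methoxyphenyl on a double-bonded chain carbon bound to a double-bonded chain carbon gives a 1.1-fold lower number from compound 1 to compound 4 (0.05 log units; within the scatter). On this read-out, therefore, the two arms cannot be told apart at this place, and a ring with one hetero atom serves as well as the methoxy-bearing carbon ring, though neither arm gives more than the modest inhibition seen across the set. Within the data shown here, compound 4 returns a number, and the only limit among the values shown belongs to compound 3: the limit of > 10000 nM in this assay, at which 1 of the 4 values shown sits.

The compounds shown leave open whether any arm at this place can separate clearly from the others, since every number reported lies within the scatter of its neighbour and the single step shown says nothing about other replacements. Going by these compounds, it also remains open how an amine or a carboxylic acid carried on the pyridin-2-yl ring, or a longer chain in place of the ring, would read in this assay.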